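Removing a methyl from the core in two analogue pairs

A few compounds are considered here, and "the series" means these few. Any claim that something is new, unique, unknown or untested is made for them only; others in the source may bear on it.

Compound 1 `Cc1cccc(COc2ccc(/C=C/C(/C=C/c3ccccn3)=N/Oc3ncnc4cccc(C)c34)cc2)c1` and compound 2 `Cc1cccc(COc2ccc(/C=C/C(/C=C/c3ccccn3)=N/Oc3ncnc4ccccc34)cc2)c1` share a framework and differ in one place. In a functional assay on SMMC-7721 cells (Homo sapiens) for inhibition, read by MTT assay, with a stated time of 72 h, tested at 10 uM (a lower number here means a weaker effect, a higher number a stronger effect of the compound at the concentration tested), compound 1 gives 97%, and compound 2 gives 97.5%. The step is a number 0.5 percentage points higher from compound 1 to compound 2 (within the scatter), and the change that makes it is hydrogen in place of methyl on an aromatic carbon.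

Compound 3 `Cc1cccc2ncnc(O/N=C(\C=C\c3ccccn3)/C=C/c3ccccc3OCc3ccc(Cl)cc3Cl)c12` is built on a different core; how its core differs from that of compound 1 is not broken down here. In this assay compound 3 gives 93.9%, which sits within the scatter of both compound 1 and compound 2, so no order among the three can be drawn.

Compound 4 `Clc1ccc(COc2ccccc2/C=C/C(/C=C/c2ccccn2)=N/Oc2ncnc3ccccc23)c(Cl)c1` has not been measured. It differs from compound 3 by hydrogen in place of methyl on an aromatic carbon. The place of this change is described in the same words as for the change from compound 1 to compound 2, so it is the same change, made on a different core.

The expectation for compound 4 rests on compound 3 and the step seen between compound 1 and compound 2. Because that step was a number 0.5 percentage points higher from compound 1 to compound 2 (within the scatter), the estimated step here is a number 0.1 percentage points higher from compound 3 to compound 4 (within the scatter), essentially no movement. In this assay compound 4 is therefore expected to give about 94%, most likely between 84% and 99%.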

Compound 4, a percentage reported as inhibition, at one concentration (the size of the read-out at that concentration, not a potency): 87.5%
For compound 4 the middle estimate is 6.5 percentage points above the measured one; measured number inside the range.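

In this assay, hydrogen in place of methyl on the core of compound 3, read as 5-methylquinazolin-4-yl to quinazolin-4-yl, comes out as a number 6.4 percentage points lower from compound 3 to compound 4 (within the scatter). Set beside the same change on the core of compound 1, the two results give no sign that the core alters what this change does: the same change on two cores in this assay, a number 0.5 percentage points higher (within the scatter) from compound 1 to compound 2 and a number 6.4 percentage points lower (within the scatter) from compound 3 to compound 4, 6.9 percentage points apart, within the scatter of two such steps This supports carrying the change from one core to the other only in a limited sense: neither step stands beyond the scatter, so the two pairs do not show that the methyl affects this read-out on either core, and they do not prove that the steps are identical or that the result would hold on any other core in the series.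

The compounds shown leave open whether a methoxy, an amine or a longer chain in place of the methyl would move the read-out beyond the scatter. They also leave open how the change would behave on a third core and whether it would give a stronger or weaker effect at another concentration, as this read-out gives the size of the effect at one concentration only.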